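Phenyl replaces a hydroxylated side chain on the ring nitrogen

The source may hold more compounds than are shown below. What is called first, only, known or untested is meant among the compounds shown, and "the series" means these compounds.

Compound 1 `CN1CCN(c2ccc(Nc3ncc4c(=O)c(-c5c(Cl)cccc5Cl)cn(C5CC5)c4n3)cc2)CC1` carries a cyclopropyl group on an aromatic nitrogen of the shared core. In a functional assay on NCI-H1299 cells (Homo sapiens) for antiproliferative activity, with a stated time of 72 h (on this read-out higher numbers stand for an effect only at larger amounts of compound and lower numbers for an effect already at smaller amounts), compound 1 gives 460 nM. Compound 2 `CN1CCN(c2ccc(Nc3ncc4c(=O)c(-c5c(Cl)cccc5Cl)cn(CC(C)(C)O)c4n3)cc2)CC1` differs only in having 2-hydroxy-2-methylpropyl at that position. On these data alone, for compound 2 this assay reports only a limit, namely > 10000 nM, so its true position is unknown beyond that boundary. The change gives an at least 21-fold higher number from compound 1 to compound 2 (1.33 log units; beyond the scatter), and the size of the loss is itself uncertain because one value sits at the limit of > 10000 nM in this assay, at which 1 of the 2 values shown sits. Compound 3 `CN1CCN(c2ccc(Nc3ncc4c(=O)c(-c5c(Cl)cccc5Cl)cn(-c5ccccc5)c4n3)cc2)CC1` is the next step: phenyl in place of 2-hydroxy-2-methylpropyl on an aromatic nitrogen. For the measured compounds named here, the one measured step that bears on it shows the hydroxylated chain costing a large amount relative to a small ring without donors or acceptors. Phenyl, like cyclopropyl, brings no donor or acceptor, so a large gain is expected, roughly an at least 16-fold lower number from compound 2 to compound 3 (1.22 log units; beyond the scatter). Compound 3 is therefore expected to give about 600 nM, plausibly between 120 nM and 6000 nM.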

Compound 3, half-maximal effective concentration: 500 nM
The estimate for compound 3 lay 1.2-fold (0.08 log units) above the measured number; the measured number falls inside the stated range.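

Phenyl sits with cyclopropyl rather than with the hydroxylated chain: in this assay, replacing 2-hydroxy-2-methylpropyl gives an at least 20-fold lower number from compound 2 to compound 3 (1.30 log units; beyond the scatter), while replacing cyclopropyl gives a 1.1-fold higher number from compound 1 to compound 3 (0.04 log units; within the scatter). This position therefore accepts a six-membered aromatic ring of carbon only as well as it accepts cyclopropyl, and no order can be drawn between compound 1 and compound 3. Among these three compounds, only compound 2, the one with a hydroxyl group, stands apart.

On these data alone, it remains open whether the loss belongs to the hydroxyl group itself or to the branched chain carrying it, a question that an isobutyl chain, or a chain ending in an amine, would help to settle. As far as these compounds go, the full size of the loss also stays unknown because compound 2 has only a limit, not a number: the limit of > 10000 nM in this assay, at which 1 of the 3 values shown sits.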